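Adding a Sulfur-Bearing Group to Compound 2

This account rests on a few compounds, and the source may have more. Where it says the series, first, only, none or still open, it means among the compounds named here.

Measured in a functional assay on A549 cells (Homo sapiens) for cytotoxicity, read by MTT assay, with a stated time of 72 h; on this read-out lower numbers stand for stronger inhibition and higher numbers for weaker inhibition:
Compound 1 `CNC(=O)c1cc(Oc2ccc(C3=NNC(c4ccc(Br)cc4)C3)cc2)ccn1`: 21000 nM
Compound 2 `CNC(=O)c1cc(Oc2ccc(C3=NNC(c4cccc(Cl)c4Cl)C3)cc2)ccn1`: 12100 nM

Compound 2, at 12100 nM, stands level with compound 1 within the scatter, with a 1.7-fold lower number from compound 1 to compound 2 (0.24 log units; within the scatter). Compound 3 `CNC(=O)c1cc(Oc2ccc(C3=NN(C(N)=S)C(c4cccc(Cl)c4Cl)C3)cc2)ccn1` differs from compound 2 by a group of 3 heavy atoms (1 carbon, 1 nitrogen, 1 sulfur; no ring) in place of a hydrogen atom, on an amine nitrogen in a ring. Among the compounds with values here, the one measured step changes a saturated ring carbon instead, so no measured step bears directly on this change. A moderate move towards a lower number is expected, though without measured precedent, and the estimated change is a 1.5-fold lower number from compound 2 to compound 3 (0.18 log units; within the scatter). Compound 3 is estimated at 8000 nM, with an expected range from 2000 nM to 25000 nM.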

Compound 3, half-maximal inhibitory concentration: > 50000 nM
Compound 3 was reported as a limit (the forecaster's own chance of this, stated with the estimate: 10%); middle value at least 6.2-fold (0.79 log units) away from the limit.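

In this assay, within the data shown here, the earlier step changed only a saturated ring carbon and stayed within the scatter, whereas the amine nitrogen in the ring is the first place where a change moves the number beyond it, with an at least 4.1-fold higher number from compound 2 to compound 3 (0.61 log units; beyond the scatter). The result for compound 3 is a limit of the assay, not a number: the limit of > 50000 nM in this assay, at which 1 of the 3 values shown sits.

The compounds shown leave open whether the sulfur itself or the added group as a whole accounts for this step, which a carboxamide or an acetyl group on this nitrogen would help separate. Going by these compounds, it also stays open whether the same step holds with the 4-bromophenyl group of compound 1 in place of the 2,3-dichlorophenyl group.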